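The source may hold more compounds than are shown below. What is called first, only, known or untested is meant among the compounds shown, and "the series" means these compounds.

Three compounds have been measured in a functional assay on B16 cells (Mus musculus), read by spectrophotometry, with a stated time of 4 days; a lower number here means a stronger inhibitor, a higher number a weaker inhibitor:
compound 1 `COc1ccc(C(=O)NCc2ccc(O)c(O)c2)c(O)c1` gives 8000 nM;
compound 2 `COc1ccc(C(=O)NCc2ccc(O)cc2O)c(O)c1` gives 27600 nM;
compound 3 `COc1ccc(C(=O)NCc2ccc(O)cc2O)c(OC)c1` gives 14200 nM.

Compound 3 and compound 2 differ in one place, (hydrogen in place of methyl on an oxygen on an aromatic ring), and that change produced a 1.9-fold higher number from compound 3 to compound 2 (0.29 log units; within the scatter). The difference between the core of compound 1 and the core of compound 3 is not broken down here. Compound 4 `O=C(NCc1ccc(O)c(O)c1)c1ccc(O)cc1O` has not yet been measured; it is related to compound 1 by the same change, (hydrogen in place of methyl on an oxygen on an aromatic ring). Within the data shown here, a step of similar size is expected, namely a 1.5-fold higher number from compound 1 to compound 4 (0.18 log units; within the scatter), because a 1.9-fold higher number from compound 3 to compound 2 (0.29 log units; within the scatter) is the only measured instance of this change. Starting from compound 1 at 8000 nM, compound 4 is estimated to give 12000 nM in this assay, most likely between 6000 nM and 25000 nM.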

Compound 4, half-maximal inhibitory concentration: 8000 nM
Beside the measured number, compound 4's estimate is 1.5-fold (0.18 log units) above it; low and high end bracket the measured number.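

In this assay, replacing methoxy with hydroxy on the core of compound 1 gave no change at the digits printed from compound 1 to compound 4 (within the scatter). The two measured instances of this change agree as far as these few numbers can tell: the same change on two cores in this assay, a 1.9-fold higher number (0.29 log units; within the scatter) from compound 3 to compound 2 and no change at the digits printed (within the scatter) from compound 1 to compound 4, 1.9-fold (0.29 log units) apart, within the scatter of two such steps. This shows that the change carried across these two cores without a step beyond the scatter, but two small steps cannot show that it would stay as small on any other core, and they give no explanation for its size.

The compounds shown leave open what a longer chain on that same oxygen would do. They also leave open whether an amine or a carboxylic acid in place of the methoxy would move the number beyond the scatter.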